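The compounds below may be only part of what the source reports. "The series", "measured", "known", "first", "only" and "open" are said of these compounds alone.

In a functional assay on KB cells (Homo sapiens) for cytotoxicity, read by spectrophotometry and crystal violet staining (on this read-out lower numbers stand for stronger inhibition and higher numbers for weaker inhibition), compound 1 `N#Cc1c(Cl)n(C2O[C@H](CF)[C@@H](O)[C@H]2O)c2cc(Cl)c(Cl)cc12` gives 50000 nM, the higher of the two actual numbers, while compound 3 `O=Cc1c(Cl)n(C2O[C@H](CF)[C@@H](O)[C@H]2O)c2cc(Cl)c(Cl)cc12` gives 20000 nM. Compound 2 `OC[C@H]1O[C@@H](n2c(Br)nc3cc(Cl)c(Cl)cc32)[C@H](O)[C@@H]1O` gives > 100000 nM, which is a limit of the assay and not a number. Compound 4 `N#Cc1c(Cl)n(C2O[C@H](CN=[N+]=[N-])[C@@H](O)[C@H]2O)c2cc(Cl)c(Cl)cc12` departs from compound 1 as follows: azido in place of fluoro on a saturated chain carbon bound to a saturated ring carbon. Within the data shown here, the only measured step, a 2.5-fold lower number from compound 1 to compound 3 (0.40 log units; beyond the scatter), is modest and concerns formyl in place of cyano on an aromatic carbon, so it bears on this change only loosely. No step beyond the scatter is therefore expected in this assay, and no direction can be favoured with confidence. The expected step is a 1.3-fold lower number from compound 1 to compound 4 (0.10 log units; within the scatter). For compound 4, the estimated value is 40000 nM, with an expected range of 12000 nM to 100000 nM.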

Compound 4, half-maximal inhibitory concentration: 60000 nM
Compound 4: the middle estimate sits 1.5-fold (0.18 log units) below what was measured; measured number inside the range.
By their numbers in this assay, from the lowest: compound 3; then compounds 1 and 4 (each within the scatter of the next). At a limit, above all of these: compound 2.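

a 1.2-fold higher number from compound 1 to compound 4 (0.08 log units; within the scatter) in this assay is the first step at this place, since the only earlier step concerned an aromatic carbon. Going from fluoromethyl to azidomethyl on a saturated chain carbon bound to a saturated ring carbon swaps one fluorine for three nitrogens, yet the step stays within the scatter. Nothing measured here bears on why the two compounds match.

The compounds shown leave open whether any group at this place would give a step beyond the scatter. An amine, a hydroxymethyl group or a carboxylic acid there remains untested in what is shown.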